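A few compounds are considered here, and "the series" means these few. Any claim that something is new, unique, unknown or untested is made for them only; others in the source may bear on it.

In an assay on CHO cells for displacement of a labelled ligand from adenosine receptor A1 (Homo sapiens), read by scintillation counting, with a stated time of 90 min, in the presence of a further agent that is not named here (a higher number here means a weaker inhibitor, a lower number a stronger inhibitor), compound 3 `CCCn1c(=O)[nH]c2nc(-c3ccc(S(=O)(=O)N4CCN(c5ccccc5F)CC4)cc3)[nH]c2c1=O` gives > 1000 nM, which is a limit of the assay and not a number. Compound 1 `CCCn1c(=O)[nH]c2nc(-c3ccc(S(=O)(=O)N4CCN(c5ccc(Cl)cc5F)CC4)cc3)[nH]c2c1=O` gives > 1000 nM, likewise a limit. Compound 2 `CCCn1c(=O)[nH]c2nc(-c3ccc(S(=O)(=O)N4CCN(c5ccccc5Br)CC4)cc3)[nH]c2c1=O` gives > 1000 nM, also a limit. Compound 3 thus stands at the limit of > 1000 nM in this assay, at which 3 of the 3 values shown sit, with no number of its own. The change to compound 4 `CCCn1c(=O)[nH]c2nc(-c3ccc(S(=O)(=O)N4CCN(Cc5ccc(Br)c(F)c5)CC4)cc3)[nH]c2c1=O` is 4-bromo-3-fluorobenzyl in place of 2-fluorophenyl on an amine nitrogen in a ring. Going by the values given here, the steps that bear on it, a step that the two limits leave unreadable from compound 1 to compound 2, a step that the two limits leave unreadable from compound 1 to compound 3 and a step that the two limits leave unreadable from compound 2 to compound 3, are all unreadable because the limit of > 1000 nM in this assay, at which 3 of the 3 values shown sit, hides them, so none of them tells how far a change on this ring nitrogen shifts this assay. Compound 4 is therefore expected to remain near the same limit, at an estimated 3000 nM within 800 nM to 20000 nM. The step that this estimate means, a step that the limit leaves unreadable from compound 3 to compound 4, is expected to lie within the scatter.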

Compound 4, inhibition constant: 326 nM
Compound 4: the middle estimate sits 9.2-fold (0.96 log units) above what was measured; the whole stated range lies above it.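

In this assay the 4-bromo-3-fluorobenzyl group on the amine nitrogen in a ring gives an at least 3.0-fold lower number from compound 3 to compound 4 (0.48 log units; beyond the scatter) and an at least 3.0-fold lower number from compound 2 to compound 4 (0.48 log units; beyond the scatter) and an at least 3.0-fold lower number from compound 1 to compound 4 (0.48 log units; beyond the scatter) so a change at this ring nitrogen can shift the read-out beyond the scatter. Going by these compounds alone, the steps among compound 1, compound 2 and compound 3 cannot be read, which makes this the first readable change at this position. The new steps give only a lower bound on the size of the change, because those three compounds sit at a limit: the limit of > 1000 nM in this assay, at which 3 of the 4 values shown sit.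

Going by these compounds, it remains open whether an unsubstituted benzyl or a longer chain such as phenethyl would shift the read-out as well. The compounds shown also do not separate the part played by the benzyl carbon from that of the bromine and fluorine.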